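Aryl replacement on the shared core: compound 2 to compound 3

This account rests on a few compounds, and the source may have more. Where it says the series, first, only, none or still open, it means among the compounds named here.

Two compounds of the series have numbers in a functional assay on OVCAR-4 cells (Homo sapiens) for inhibition, read by sulforhodamine B assay, with a stated time of 48 h, tested at 10 uM; a lower number here means less inhibition, a higher number more inhibition at the concentration tested (going by the name of the read-out). Compound 1 `Brc1ccc(-c2cn3ccnc3c(-c3ccc4ncn(C5CCCCC5)c4c3)n2)cc1` gives 10.5% in this assay. Compound 2 `CCc1ccc(-c2cn3ccnc3c(-c3ccc4ncn(Cc5ccccc5)c4c3)n2)cc1` gives 35.1% in this assay, the higher of the two numbers, and the gap to compound 1 lies beyond the usual scatter of repeated runs. Among the measured compounds shown here, no two measured compounds differ in one place only, so no measured step is available, and the pair gives no guide to how a single exchange of an aromatic group moves the read-out.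

Compound 3 `c1ccc(Cn2cnc3ccc(-c4nc(-c5cccc6ccccc56)cn5ccnc45)cc32)cc1` has not been measured. Its difference from compound 2 is naphthalen-1-yl in place of 4-ethylphenyl on an aromatic carbon. The group that leaves and the group that enters are both carbon-only aromatic systems without donors or acceptors, so the change is one of shape and size only.

For the measured compounds named here, with no step of this kind on hand, the step from compound 2 to compound 3 is expected to be small, a number 3.1 percentage points lower from compound 2 to compound 3 (within the scatter), and not beyond the scatter. Compound 3 is estimated at 32% in this assay, with a range from 12% to 55%.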

Compound 3, a percentage reported as inhibition, at one concentration (the size of the read-out at that concentration, not a potency): 7.88%
Compound 3: the middle estimate sits 24.1 percentage points above what was measured, outside the stated range (below it).
By their numbers in this assay, from the lowest: compounds 3 and 1 (each within the scatter of the next); then compound 2.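

Among the compounds shown here, the step of a number 27.2 percentage points lower from compound 2 to compound 3 (beyond the scatter) is the first single-place comparison, and it shows that this position, on an aromatic carbon next to the ring nitrogen, is not indifferent to the aromatic group it carries in this assay. Naphthalen-1-yl and 4-ethylphenyl both have no hydrogen-bond donors or acceptors and no net charge, so an exchange between two carbon-only aromatic groups, one with 2 six-membered rings and the other with one ring and an ethyl group, is enough on its own to move the read-out beyond the scatter. The data at hand offer no measured basis for explaining this step.

This single step cannot separate the contribution of the second aromatic ring from that of the lost ethyl group, and a plain phenyl at the same position would be the group to tell the two apart. Also open, on these data alone, is how the read-out responds when the ring at this position carries an amine, a carboxylic acid or a longer chain such as butyl in place of the ethyl group.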